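Chloro-to-methyl swap on the hydroxamate ring

The source may report more compounds than this note shows. Statements on the series, on what has been measured and on what is new or still open speak of the compounds shown alone.

Compound 1 `COc1ccc(C(C)=O)cc1NC(=O)c1cc(C(=O)NO)ccc1Cl`: 90 nM in an assay on isolated protein for inhibition of histone deacetylase 8 (Homo sapiens), read by fluorescence, with a stated time of 90 min; a lower number here means a stronger inhibitor, a higher number a weaker inhibitor
Compound 2 `CCOc1ccc(C(C)=O)cc1NC(=O)c1cc(C(=O)NO)ccc1Cl`: 220 nM in this assay

Compound 1 holds the lowest of the two numbers; its nearest neighbour is compound 2, reached by a 2.4-fold higher number from compound 1 to compound 2 (0.39 log units; beyond the scatter). Compound 3 `COc1ccc(C(C)=O)cc1NC(=O)c1cc(C(=O)NO)ccc1C` differs from compound 1 by methyl in place of chloro on an aromatic carbon. Among the measured compounds shown here, no measured step touches that ring: the only step in hand is a 2.4-fold higher number from compound 1 to compound 2 (0.39 log units; beyond the scatter), a change on the alkoxy chain, so it gives no direct guide here. For the measured compounds named here, with no precedent, the expected step is none beyond the scatter, no change at the digits printed from compound 1 to compound 3 (within the scatter). Compound 3 is therefore estimated at 90 nM, with a range of 40 nM to 250 nM, in this assay.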

Compound 3, half-maximal inhibitory concentration: 90 nM
Beside the measured number, compound 3's estimate shows no gap at the digits printed, within the range that was stated.
By their numbers in this assay, from the lowest: compounds 1 and 3 (each within the scatter of the next); then compound 2.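

The aromatic carbon para to a hydroxycarbamoyl group accepts methyl in place of chloro without a readable shift in this assay (no change at the digits printed from compound 1 to compound 3 (within the scatter)). Among the compounds shown here, this is the first reading at this position, and it shows that chloro is not required there to keep the number of compound 1. No available evidence explains this equivalence. 

Still open, on these data alone, is how an amine, a methoxy group or a longer chain would read at this carbon. Also open, as far as these compounds go, is whether the ethoxy step seen with chloro carries over to the methyl series.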